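Working notes: replacing the side chain of compound 2

The source may hold more compounds than are shown below. What is called first, only, known or untested is meant among the compounds shown, and "the series" means these compounds.

Measured compounds:
- compound 1 (`Cc1nc(N(C)c2ccc([Se]C#N)c(C)c2)c2ccccc2n1`): 9 nM
- compound 2 (`COc1ccc(N(C)c2nc(C)nc3ccccc23)cc1C(=O)NCC[Se]C#N`): 179 nM

Both values come from a functional assay on HepG2 cells (Homo sapiens) for inhibition, read by MTT assay, with a stated time of 48 h (on this read-out higher numbers stand for weaker inhibition and lower numbers for stronger inhibition), and lie beyond the scatter of each other, with compound 2 holding the higher number of the two. Compound 3 (`COc1ccc(N(C)c2nc(C)nc3ccccc23)cc1C[Se]C#N`) departs from compound 2 by one change, (a group of 4 heavy atoms (2 carbon, 1 nitrogen, 1 selenium; no ring) in place of a group of 8 heavy atoms (4 carbon, 2 nitrogen, 1 oxygen, 1 selenium; no ring), on an aromatic carbon), placed ortho to a methoxy group. Among the compounds with values here, no measured step covers this change. Within the data shown here, the only guide is compound 1 at 9 nM, so a drop towards stronger inhibition, beyond the scatter, is expected. The expected size is a 3.6-fold lower number from compound 2 to compound 3 (0.55 log units; beyond the scatter) in this assay for this change. For compound 3 the estimated value is 50 nM (expected range 12 nM to 200 nM).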

Compound 3, half-maximal inhibitory concentration: 1110 nM
Compound 3: the middle estimate sits 22-fold (1.35 log units) below what was measured, and the stated range ends below it.
By their numbers in this assay, from the lowest: compound 1; then compound 2; then compound 3.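

In this assay, the group of 4 heavy atoms in place of the group of 8 heavy atoms, ortho to a methoxy group, gives a 6.2-fold higher number from compound 2 to compound 3 (0.79 log units; beyond the scatter): this position responds to the side chain, and here the smaller group goes with weaker inhibition. Compound 1 differs from both in more than one place, so it does not bear on this change. No measurement at hand accounts for the step.

Still open, as far as these compounds go, is how a longer chain without the carbonyl, or an amine in the same place, would read in this assay. The shown pair cannot separate chain length from the presence of the carbonyl and the amide hydrogen.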